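The source may hold more compounds than are shown below. What is called first, only, known or untested is meant among the compounds shown, and "the series" means these compounds.

Compound 1 `CC(C)(C)OC(=O)Nc1ncc(C(Oc2ccc3cc(Br)ccc3c2)c2ccc(Cl)cc2)s1`: > 50000 nM in an ADME assay on HepG2 2.2.15 cells (Homo sapiens) for cytotoxicity; on this read-out lower numbers stand for higher toxicity in this test and higher numbers for lower toxicity in this test.
Compound 2 `O=C(Nc1ncc(C(Oc2ccc3cc(Br)ccc3c2)c2ccc(Cl)cc2)s1)c1cccs1`: "not toxic" (no number reported) in this assay.

The figure given for compound 1 is a limit of the assay, not a measured number. For compound 2 no number is reported at all, only the statement that it caused no toxicity. Taken together, the measured compounds sit at the limit of > 50000 nM in this assay, at which 1 of the 2 values shown sits, or beside it with a description in place of a value. Compound 3 `CCCCC(CC)CNc1ncc(C(Oc2ccc3cc(Br)ccc3c2)c2ccc(Cl)cc2)s1` has not been measured yet. Its change from compound 2 is 2-ethylhexyl in place of (thiophen-2-yl)carbonyl on a nitrogen on an aromatic ring. For the measured compounds named here, no step between two measured compounds exists, so the size and direction of this change cannot be read from the data; the expectation is a step of no size beyond the usual scatter, with wide uncertainty. Compound 3 is estimated at 40000 nM in this assay, with a range from 10000 nM to 100000 nM.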

Compound 3, half-maximal cytotoxic concentration: "not toxic" (no number reported)
No number was reported for compound 3, and the estimate cannot be compared.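

No step can be read from compound 2 to compound 3, since this assay describes both only as not toxic and gives no number. The compounds shown leave open at what concentration any of them would harm these cells, and the data stop at a limit: the limit of > 50000 nM in this assay, at which 1 of the 3 values shown sits.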